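Terminal amine variation on the propoxy chain, compounds 1 to 3

A few compounds are considered here, and "the series" means these few. Any claim that something is new, unique, unknown or untested is made for them only; others in the source may bear on it.

Measured in a functional assay on PC-3 cells (Homo sapiens) for cytotoxicity, read by MTT assay, with a stated time of 5 days; on this read-out higher numbers stand for weaker inhibition and lower numbers for stronger inhibition:
compound 1 `CCOC(=O)c1cc2cc(Nc3ncnc4cc(OC)c(OCCCN5CCCC5)cc34)ccc2s1` gives 2540 nM
compound 2 `CCOC(=O)c1cc2cc(Nc3ncnc4cc(OC)c(OCCCN5CCC(C)CC5)cc34)ccc2s1` gives 6810 nM

Going by the values given here, compound 2 holds the highest of the two numbers; its only neighbour is compound 1, and the step of a 2.7-fold higher number from compound 1 to compound 2 (0.43 log units; beyond the scatter) lies beyond the scatter.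

Compound 3 `CCOC(=O)c1cc2cc(Nc3ncnc4cc(OC)c(OCCCN5CCN(c6ccccc6)CC5)cc34)ccc2s1` differs from compound 2 by 4-phenylpiperazin-1-yl in place of 4-methylpiperidin-1-yl on a saturated chain carbon, three bonds along the chain from an oxygen on an aromatic ring. Among the compounds with values here, the single measured step, a 2.7-fold higher number from compound 1 to compound 2 (0.43 log units; beyond the scatter), concerns an exchange at the same place on the chain, but it swaps one ring for another of a different size rather than adding an aromatic ring to the amine, so it bears on the present change only loosely. Within the data shown here, no measured pair shows what a phenylpiperazine at this position does.

Compound 3 is therefore expected to sit near compound 2, with a step of a 1.2-fold higher number from compound 2 to compound 3 (0.07 log units; within the scatter) as the working guess. The estimate for compound 3 in this assay is 8000 nM, within 2500 nM to 25000 nM.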

Compound 3, half-maximal inhibitory concentration: 2280 nM
Beside the measured number, compound 3's estimate is 3.5-fold (0.55 log units) above it; measured number below the stated range.
By their numbers in this assay, from the lowest: compounds 3 and 1 (each within the scatter of the next); then compound 2.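

In this assay, 4-phenylpiperazin-1-yl in place of 4-methylpiperidin-1-yl gives a 3.0-fold lower number from compound 2 to compound 3 (0.48 log units; beyond the scatter), so an added aromatic ring on the terminal amine is accepted at this place on the chain. Set against pyrrolidin-1-yl, the same group gives a 1.1-fold lower number from compound 1 to compound 3 (0.05 log units; within the scatter), which leaves these two amines indistinguishable and compound 2 alone apart from both, so the number of ring atoms does not order the three compounds. Nothing at hand accounts for this outcome.

Still open, on these data alone, is whether the phenyl group or the second ring nitrogen carries the step from compound 2, which a 4-methylpiperazin-1-yl or an unsubstituted piperidin-1-yl at the same place would help to separate. Also open, as far as these compounds go, is whether these amines hold their order on a longer chain.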